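The source may report more compounds than this note shows. Statements on the series, on what has been measured and on what is new or still open speak of the compounds shown alone.

Working notes on the series. Compound 2 `C#CCNC(=O)/C(C)=C(\C)c1ccc(Br)cc1` in a toxicity assay on the whole organism (strain Icem-CET (SPF Caw)) for cytotoxicity, with Mus musculus as the target (a lower number here means that less compound is needed, a higher number that more compound is needed for the effect), gives 500 mg/kg; compound 1 `C/C(C(=O)NC1CC1)=C(\C)c1ccc(Br)cc1` in this assay gives 450 mg/kg, and the two numbers lie within the scatter of each other, so neither compound sets itself apart. Compound 3 `C/C(C(=O)NC1CC1)=C(/C)c1ccc(Br)cc1` is to be measured in this assay. It differs from compound 2 by cyclopropyl in place of propargyl on an amide-type nitrogen. For the measured compounds named here, no comparable step is on record, so the change is expected to move the number by no more than the scatter, in no set direction; compound 3 is expected to give 470 mg/kg (from 300 mg/kg to 750 mg/kg) in this assay, a step of a 1.1-fold lower number from compound 2 to compound 3 (0.03 log units; within the scatter).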

Compound 3, dose for half-maximal effect: 600 mg/kg
Compound 3: the middle estimate sits 1.3-fold (0.11 log units) below what was measured; the measured number falls inside the stated range.
By their numbers in this assay, from the lowest: compounds 1, 2 and 3 (each within the scatter of the next).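

Cyclopropyl in place of propargyl on an amide-type nitrogen comes with a 1.2-fold higher number from compound 2 to compound 3 (0.08 log units; within the scatter) in this assay, so at this position a three-membered ring and a triple-bond chain are not told apart. The double-bond configuration is not told apart either, with a 1.3-fold higher number from compound 1 to compound 3 (0.12 log units; within the scatter). This pair gives the first reading on configuration alone: the fact that compounds 1 and 3 differ only in the configuration as drawn

Open, on these data alone, is whether an amine, a carboxylic acid or a longer chain on that nitrogen would give a number beyond the scatter in this assay.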